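This account rests on a few compounds, and the source may have more. Where it says the series, first, only, none or still open, it means among the compounds named here.

Compound 1 `Cc1nc2c(Br)c(Br)c(Br)c(Br)c2n1CC#N` gives 14% in a functional assay on CCRF-CEM cells (Homo sapiens) for cytotoxicity, read by MTT assay, with a stated time of 24 h, tested at 20 uM; a lower number here means a stronger effect, a higher number a weaker effect of the compound at the concentration tested.
Compound 2 `Cc1nc2c(Br)c(Br)c(Br)c(Br)c2n1CCCCC#N` gives 61% in this assay.

Of these two numbers, compound 2 stands highest, meaning the weaker effect at the concentration tested. For the measured compounds named here, the one measured step, a number 47 percentage points higher from compound 1 to compound 2 (beyond the scatter), comes from a 3-cyanopropyl in place of cyano on a saturated chain carbon bound to an aromatic nitrogen, a change in the chain on the ring nitrogen.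

Compound 3 `N#CCCCCn1cnc2c(Br)c(Br)c(Br)c(Br)c21` differs from compound 2 elsewhere: hydrogen in place of methyl on an aromatic carbon. Going by the values given here, the change sits on the shared core, not on the chain, so the step from compound 1 to compound 2 does not bear on it directly, and no other measured step touches that ring carbon. With nothing in the measured numbers pointing either way, the expectation for this assay is no step beyond the scatter: compound 3 is estimated to lie close to compound 2, with an expected step of a number 3 percentage points lower from compound 2 to compound 3 (within the scatter). The expected value for compound 3 in this assay is 58%, within a range from 35% to 80%.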

Compound 3, a percentage reported as activity, at one concentration (the size of the read-out at that concentration, not a potency): 70%
Compound 3: middle estimate off by 12 percentage points, on the low side; the range from low to high includes it.
By their numbers in this assay, from the lowest: compound 1; then compounds 2 and 3 (each within the scatter of the next).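

For the compounds shown here, at the aromatic carbon between two ring nitrogen atoms, the first change to the shared core gives a number 9 percentage points higher from compound 2 to compound 3 (within the scatter) in this assay and so cannot be told apart from repeat-to-repeat variation. With a 4-cyanobutyl group on the ring nitrogen, the methyl at this carbon therefore makes no difference that this test can resolve, whereas the change in the chain gives a number 47 percentage points higher from compound 1 to compound 2 (beyond the scatter) and stands out clearly. No supporting data are available to explain either result.

Hydrogen and methyl are only two small options, so it remains open whether a larger or different group at this carbon, such as an amine, an ethyl group or a phenyl ring, would also leave the read-out within the scatter or would shift it clearly. Going by these compounds alone, it is also open whether the same swap of methyl for hydrogen would stay within the scatter on compound 1, whose shorter chain gives a much stronger effect at the concentration tested, since the present step was seen only with the longer chain.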